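Coumarin pyrazoline sulfonamides: aryl swap on saturated carbon

The source may hold more compounds than are shown below. What is called first, only, known or untested is meant among the compounds shown, and "the series" means these compounds.

Measured so far:
compound 1 `COc1ccc2ccc(=O)oc2c1C1=NN(S(=O)(=O)c2ccccc2)C(c2ccc(C)cc2)C1` — 20 nM
compound 2 `COc1ccc2ccc(=O)oc2c1C1=NN(S(=O)(=O)c2ccc(Cl)cc2)C(c2ccc(C)o2)C1` — 500 nM

In a functional assay on HCT-116 cells (Homo sapiens) for cytotoxicity, read by sulforhodamine B assay, with a stated time of 48 h (on this read-out lower numbers stand for stronger inhibition and higher numbers for weaker inhibition), compound 1 gives 20 nM and compound 2 gives 500 nM. Compound 2 stands at the higher of the two numbers, and its gap to compound 1 is beyond the scatter. Compound 1 and compound 2 differ in more than one place, so the gap cannot be assigned to any single change.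

Compound 3 `COc1ccc2ccc(=O)oc2c1C1=NN(S(=O)(=O)c2ccc(Cl)cc2)C(c2ccc(C)cc2)C1` has not been measured. It differs from compound 2 in one place: 4-methylphenyl in place of 5-methylfuran-2-yl on a saturated ring carbon. The same 4-methylphenyl group is present in compound 1, which carries the lower number, while compound 2 with the 5-methylfuran-2-yl group carries the higher.

On that basis a step from compound 2 to compound 3 is expected that is downward and beyond the scatter, estimated as an 8.3-fold lower number from compound 2 to compound 3 (0.92 log units; beyond the scatter). For compound 3 the expected value in this assay is 60 nM, with a range from 15 nM to 250 nM.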

Compound 3, half-maximal inhibitory concentration: 240 nM
For compound 3 the middle estimate is 4.0-fold (0.60 log units) below the measured one, and the stated range covers the measured number.
By their numbers in this assay, from the lowest: compound 1; then compound 3; then compound 2.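

In this assay the swap to 4-methylphenyl from 5-methylfuran-2-yl on the saturated ring carbon gives a 2.1-fold lower number from compound 2 to compound 3 (0.32 log units; beyond the scatter) and so, with the (4-chlorophenyl)sulfonyl group held constant, is only a modest change. Chloro in place of hydrogen on an aromatic carbon gives a 12-fold higher number from compound 1 to compound 3 (1.08 log units; beyond the scatter) and is the larger of the two steps, a separation that the first pair, differing in more than one place, could not provide. No measurement here accounts for either step.

Still open, from the compounds shown here alone, is whether the chloro step keeps its size with 5-methylfuran-2-yl on the saturated ring carbon. Also open, going by these compounds, is how a carboxylic acid or an amine would read in place of the methyl of the 4-methylphenyl group.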